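The source may hold more compounds than are shown below. What is called first, only, known or untested is meant among the compounds shown, and "the series" means these compounds.

Measured so far:
- compound 1 `CC1=CC[C@H](C(C)C)c2cc(C)c(OC(=O)c3cccc(C)c3)cc21`: "not active" (no number reported)
- compound 2 `CC1=CC[C@H](C(C)C)c2cc(C)c(OC(=O)c3cccc([N+](=O)[O-])c3)cc21`: 60.4%

In a functional assay on SK-LU-1 cells (Homo sapiens) for antiproliferative activity, read by sulforhodamine B assay, with a stated time of 48 h, tested at 50 uM (a lower number here means less inhibition, a higher number more inhibition at the concentration tested (going by the name of the read-out)), compound 2 gives 60.4%, the only number among the two compounds shown, as compound 1 is reported without a number. Compound 3 `CC1=CC[C@H](C(C)C)c2cc(C)c(OC(=O)Nc3ccccc3)cc21` is not yet measured. It differs from compound 2 in one place: anilino in place of 3-nitrophenyl on a carbonyl carbon. Among the measured compounds shown here, no measured pair shows a step of this kind, so the size is open. Losing the nitro group while moving from an ester to a carbamate is expected to cost some inhibition; the step of a number 25.4 percentage points lower from compound 2 to compound 3 (beyond the scatter) is estimated to fall beyond the scatter, downward. Compound 3 is expected to give about 35%, between 5% and 65%.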

Compound 3, a percentage reported as inhibition, at one concentration (the size of the read-out at that concentration, not a potency): 100%
Estimate against measurement, compound 3: 65 percentage points below, and the stated range ends below it.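

In this assay, the step of a number 39.6 percentage points higher from compound 2 to compound 3 (beyond the scatter) comes with anilino in place of 3-nitrophenyl on the carbonyl carbon. At this position, then, the nitro group is not needed for inhibition, and a ring attached through nitrogen is accepted on this core. Nothing measured here explains the rise. The swap changes the link and removes the nitro group together, and the two cannot be separated from these compounds. An anilino ring carrying a nitro group, or a simple ethyl chain in place of the ring, would help to tell them apart.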